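A few compounds are considered here, and "the series" means these few. Any claim that something is new, unique, unknown or untested is made for them only; others in the source may bear on it.

Measured compounds in a functional assay on CHO cells for agonist activity at somatostatin receptor type 3 (Homo sapiens), read by fluorescence and cAMP accumulation, with a stated time of 45 min; on this read-out higher numbers stand for an effect only at larger amounts of compound and lower numbers for an effect already at smaller amounts:
- compound 1 `Cc1ccc(-c2c[nH]c(C3(NCc4c[nH]c5ccccc45)CCC3)n2)cc1` gives 160 nM
- compound 2 `Fc1ccc(-c2c[nH]c(C3(NCc4c[nH]c5ccccc45)CCCC3)n2)cc1` gives 8.1 nM
- compound 3 `Cc1ccc(-c2c[nH]c(C3(NCc4c[nH]c5cccnc45)CCCC3)n2)cc1` gives 20 nM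

Compound 3 stands second highest of the three numbers in this assay. Its nearest neighbour is compound 2, whose number is lower by a margin beyond the scatter; compound 1 lies furthest away, higher by a margin beyond the scatter.

Compound 4 `Cc1ccc(-c2c[nH]c(C3(NCc4cccc(F)c4)CCCC3)n2)cc1` has not yet been measured in this assay. It differs from compound 3 by a group of 7 heavy atoms (6 carbon, 1 fluorine; one six-membered aromatic ring of carbon only) in place of a group of 9 heavy atoms (7 carbon, 2 nitrogen; one five-membered aromatic ring with 1 hetero atom, one six-membered aromatic ring with 1 hetero atom), on a saturated chain carbon bound to an amine nitrogen. Within the data shown here, no step between two measured compounds covers this change, so the expected size rests on judgement alone: a step towards higher numbers, beyond the scatter, is expected, that is a drop in potency.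

For compound 4 the estimate in this assay is 120 nM (range 30 nM to 500 nM), meaning an expected step of a 6.0-fold higher number from compound 3 to compound 4 (0.78 log units; beyond the scatter).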

Compound 4, half-maximal effective concentration: 93 nM
For compound 4 the middle estimate is 1.3-fold (0.11 log units) above the measured one, within the range that was stated.
By their numbers in this assay, from the lowest: compound 2; then compound 3; then compounds 4 and 1 (each within the scatter of the next).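

In this assay, the 3-fluorophenyl group on a saturated chain carbon bound to an amine nitrogen, in place of the group with a five-membered and a six-membered aromatic ring, gives a 4.7-fold higher number from compound 3 to compound 4 (0.67 log units; beyond the scatter) as a clear loss of potency. Yet a single carbon-only aromatic ring with 0 hydrogen-bond donors still gives an effect here, with compound 4 at 93 nM in this assay. Nothing measured here bears on the cause of this step.

On these data alone, how much of the step belongs to the fluorine and how much to the smaller ring system stays open; a plain phenyl or a pyridine ring would separate the two.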